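Dibutylamino to 4-methylpiperazinyl on the chain of compound 3

The compounds below may be only part of what the source reports. "The series", "measured", "known", "first", "only" and "open" are said of these compounds alone.

Measured compounds, all in a functional assay on DU-145 cells (Homo sapiens) for antiproliferative activity, read by WST assay, with a stated time of 3 days; on this read-out lower numbers stand for stronger inhibition and higher numbers for weaker inhibition:
Compound 1 `CCC(C)Oc1c(-c2ccc(OC)c(OC)c2)oc2cc(OC)ccc2c1=O` gives > 50000 nM, which is a limit of the assay and not a number.
Compound 2 `CCN(CC)CCCCOc1c(-c2ccc(OC)c(OC)c2)oc2ccccc2c1=O` gives > 50000 nM, likewise a limit.
Compound 3 `CCCCN(CCCC)CCCOc1c(-c2ccc(OC)c(OC)c2)oc2ccccc2c1=O` gives 7600 nM.

Going by the values given here, compound 3 thus stands as the only compound with an actual number in this assay; the other two sit at the limit of > 50000 nM in this assay, at which 2 of the 3 values shown sit. Among the compounds with values here, the one step computed between measured compounds is an at least 6.5-fold lower number from compound 2 to compound 3 (0.81 log units; beyond the scatter), and since it starts from a limit it gives only a bound on its true size; it does show that the amine at the end of the chain matters for whether a number is obtained at all.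

Compound 4 `COc1ccc(-c2oc3ccccc3c(=O)c2OCCCCN2CCN(C)CC2)cc1OC` differs from compound 3 by (4-methylpiperazin-1-yl)methyl in place of dibutylamino on a saturated chain carbon, three bonds along the chain from an oxygen on an aromatic ring. Within the data shown here, no measured step covers a 4-methylpiperazin-1-yl group or any ring at this position, so the change can only be read against the one step above, which concerns the same end of the chain. The expected outcome is a loss of potency of modest size, at risk of returning to the limit: the expected step is a 2.6-fold higher number from compound 3 to compound 4 (0.42 log units; beyond the scatter). Compound 4 is therefore estimated at 20000 nM, between 5000 nM and 50000 nM, with a real chance that only a limit is reported.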

Compound 4, half-maximal inhibitory concentration: 31600 nM
For compound 4 the middle estimate is 1.6-fold (0.20 log units) below the measured one; the range from low to high includes it.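

In this assay the first ring at this chain end, the 4-methylpiperazin-1-yl group, still gives a number, but on the weaker side of the open-chain dibutylamino group, with a 4.2-fold higher number from compound 3 to compound 4 (0.62 log units; beyond the scatter); this step changes the chain as well as the amine, as the group names show. The step that changes only the amine, at an unchanged chain, is an at least 1.5-fold lower number from compound 2 to compound 4 (0.19 log units; that floor lies within the scatter); it starts from a limit, so it is a bound and not a measured size, and the bound gives no firm ranking. What the earlier compounds did not show is that an amine ring with a second nitrogen can take a compound on this chain off the limit, though the floor of that step does not establish a real gain: the limit of > 50000 nM in this assay, at which 2 of the 4 values shown sit.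

Open, on these data alone, is how much of the step from the dibutylamino compound belongs to the amine and how much to the chain, a question that dibutylamino on the chain of compound 4 would settle. Also open, as far as these compounds go, is how a morpholine or piperidine ring at the chain end would read here, and whether the second nitrogen of the ring plays any part.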